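The compounds below may be only part of what the source reports. "The series", "measured", "known", "first", "only" and "open" are said of these compounds alone.

Three compounds have numbers in a functional assay (trachea) for antagonist activity, with Cavia porcellus as the target; on this read-out higher numbers stand for higher potency (the scale is a negative logarithm) and lower numbers for lower potency:

compound 1, `COc1ccc(OC)c(S(=O)(=O)NC(=O)c2ccc(Cn3ccc4ccc(NC(=O)CC5CCCC5)cc43)c(OC)c2)c1`, 9.1
compound 2, `COc1cc(C(=O)NS(=O)(=O)c2ccccc2C)ccc1Cn1ccc2ccc(NC(=O)CC3CCCC3)cc21`, 9.9
compound 3, `COc1cc(C(=O)NS(=O)(=O)c2cc(C)ccc2C)ccc1Cn1ccc2ccc(NC(=O)CC3CCCC3)cc21`, 8.4

Compound 3 stands lowest of the three in this assay. Its nearest neighbour is compound 1, and the step between them is a number 0.70 log units lower from compound 1 to compound 3 (beyond the scatter). The furthest is compound 2, with a number 1.50 log units lower from compound 2 to compound 3 (beyond the scatter), while the remaining step reads a number 0.80 log units higher from compound 1 to compound 2 (beyond the scatter). All three changes touch only the aryl group on the sulfonyl sulfur.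

Compound 4, `COc1cc(C(=O)NS(=O)(=O)c2c(C)cccc2Cl)ccc1Cn1ccc2ccc(NC(=O)CC3CCCC3)cc21`, has not been measured. Compared with compound 3 the difference is 2-chloro-6-methylphenyl in place of 2,5-dimethylphenyl on a sulfonyl sulfur. Among the measured compounds shown here, the steps that bear on it are those among compounds 1, 2 and 3, since each of them also exchanges this aryl group. They show that a single methyl on the ring, as in compound 2, gives the highest number, and that adding a second methyl, as in compound 3, costs a large step. For the measured compounds named here, compound 4 keeps two substituents on the ring, but one of them is chlorine rather than methyl, and no step here tells how chlorine compares. Compound 4 is therefore expected to stay near compound 3, with a change of about a number 0.30 log units higher from compound 3 to compound 4 (within the scatter) expected in this assay, not clearly beyond the scatter. The estimate for compound 4 is 8.7, with a range from 7.9 to 9.5.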

Compound 4, negative logarithm of the antagonist equilibrium constant: 8.8
Compound 4: middle estimate off by 0.10 log units, on the low side; low and high end bracket the measured number.
By their numbers in this assay, from the lowest: compound 3; then compounds 4 and 1 (each within the scatter of the next); then compound 2.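

In this assay, the exchange of 2,5-dimethylphenyl for 2-chloro-6-methylphenyl on the sulfonyl sulfur gives a number 0.40 log units higher from compound 3 to compound 4 (beyond the scatter), so a ring with two substituents is not tied to the number of compound 3, even though the count of 8 heavy atoms stays the same. That recovery remains partial, with a number 1.10 log units lower from compound 2 to compound 4 (beyond the scatter), which leaves compound 2 and its 2-methylphenyl group ahead, while a number 0.30 log units lower from compound 1 to compound 4 (within the scatter) means that 2-chloro-6-methylphenyl and 2,5-dimethoxyphenyl cannot be told apart at this position. No measurement at hand accounts for any of these differences.

The step from compound 3 to compound 4 replaces a methyl with chlorine and also changes the substitution pattern of the ring, so the compounds shown do not separate the contribution of the chlorine from that of the new arrangement. On these data alone, a 2-chlorophenyl group, with chlorine as the only ring substituent, would make that comparison directly against the 2-methylphenyl group of compound 2, and how bromine or a trifluoromethyl group would fare on this ring also remains open.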